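Amino for chloro on the second benzyl core

A few compounds are considered here, and "the series" means these few. Any claim that something is new, unique, unknown or untested is made for them only; others in the source may bear on it.

Measured in a functional assay on NCI-H23 cells (Homo sapiens) for cytotoxicity, read by sulforhodamine B assay, with a stated time of 48 h; on this read-out lower numbers stand for stronger inhibition of growth and higher numbers for weaker inhibition of growth:
compound 1, `ClCc1ccccc1Cn1cnc2c(Cl)nc(Cl)nc21`: 1510 nM
compound 2, `ClCc1cccc(Cn2cnc3c(Cl)nc(Cl)nc32)c1`: 2130 nM
compound 3, `Nc1nc(Cl)c2ncn(Cc3ccccc3CCl)c2n1`: 3020 nM

Compound 1 and compound 2 are built from the same atoms joined differently; the difference between the two cores is not broken down here. In this assay the values of compound 1 and compound 2 lie within the scatter of each other, so no order between them is claimed.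

Compound 3 follows from compound 1 by amino in place of chloro on an aromatic carbon. The measured step is a 2.0-fold higher number from compound 1 to compound 3 (0.30 log units; within the scatter), which is within the scatter.

Compound 4, `Nc1nc(Cl)c2ncn(Cc3cccc(CCl)c3)c2n1`, is not yet measured. It follows from compound 2 by amino in place of chloro on an aromatic carbon. The place description is the same word for word as for the change from compound 1 to compound 3, so this is the same change on the other core.

Among the compounds with values here, with only one measured instance to go on, the expected step is a 2.0-fold higher number from compound 2 to compound 4 (0.29 log units; within the scatter), resting on the step of a 2.0-fold higher number from compound 1 to compound 3 (0.30 log units; within the scatter) seen on the first core. On that basis compound 4 is estimated at 4200 nM, with a likely range from 2000 nM to 9000 nM in this assay.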

Compound 4, concentration for 50% growth inhibition: 2040 nM
Compound 4: middle estimate off by 2.1-fold (0.31 log units), on the high side, within the range that was stated.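

In this assay, amino in place of chloro on an aromatic carbon on the core of compound 2 gives (a 1.0-fold lower number from compound 2 to compound 4 (0.02 log units; within the scatter)), so the change leaves this core's number within the scatter. Set beside the earlier instance, the two steps do not differ: the same change on two cores in this assay, a 2.0-fold higher number (0.30 log units; within the scatter) from compound 1 to compound 3 and a 1.0-fold lower number (0.02 log units; within the scatter) from compound 2 to compound 4, 2.1-fold (0.32 log units) apart, within the scatter of two such steps. The change therefore carries across these two cores without a step that stands clear of the scatter on either one, but this does not show that it has a shared effect of any real size, and two pairs of compounds say nothing about cores beyond these.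

The compounds shown leave open whether a different group on that aromatic carbon, such as a methoxy group, a morpholine or a longer amine chain, would move the number beyond the scatter. Also open, going by these compounds, is how the same change reads outside this assay on either core.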